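One Methoxy Fewer Where No Compound Yet Acts

A few compounds are considered here, and "the series" means these few. Any claim that something is new, unique, unknown or untested is made for them only; others in the source may bear on it.

Of the compounds shown here, three sharing one core have been measured in a functional assay on NCI-H460 cells (Homo sapiens) for cytotoxicity, read by sulforhodamine B assay, with a stated time of 48 h, tested at 0.1 uM; a higher number here means a weaker effect of the compound at the concentration tested, a lower number a stronger effect. Compound 1 `COc1ccc(-c2cc(/C=C/C(=O)c3ccc(N)cc3)[nH]n2)cc1` gives 102% in this assay, compound 2 `COc1cc(-c2cc(/C=C/C(=O)c3ccc(N)cc3)[nH]n2)cc(OC)c1OC` gives 102%, and compound 3 `COc1ccc(C(=O)/C=C/c2cc(-c3cc(OC)c(OC)c(OC)c3)n[nH]2)cc1OC` gives 101%. Compound 2 stands level with compound 1 at the digits shown, and the two together are the highest of the three numbers, while the single measured step, a number 1 percentage points lower from compound 2 to compound 3 (within the scatter), is within the scatter. At the concentration tested, none of the three shows an effect that rises out of the noise.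

Compound 4 `COc1ccc(-c2cc(/C=C/C(=O)c3ccc(N)cc3)[nH]n2)cc1OC` differs from compound 2 in one place: hydrogen in place of methoxy on an aromatic carbon. Among the measured compounds shown here, no measured step removes a methoxy group; the only step available puts 3,4-dimethoxyphenyl in place of 4-aminophenyl on a carbonyl carbon and left the number essentially where it was. With compound 1, compound 2 and compound 3 all reading the same height in this assay, nothing suggests that one methoxy less would move the number. Compound 4 is therefore expected to give 101% in this assay, within 93% to 108%. The expected step of a number 1 percentage points lower from compound 2 to compound 4 (within the scatter) is none beyond the scatter.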

Compound 4, a percentage reported as activity, at one concentration (the size of the read-out at that concentration, not a potency): 100%
For compound 4 the middle estimate is 1 percentage points above the measured one, within the range that was stated.
By their numbers in this assay, from the lowest: compounds 4, 3, 1 and 2 (each within the scatter of the next).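

Hydrogen in place of methoxy on this aromatic carbon now has a reading of its own in this assay: the removal gives a number 2 percentage points lower from compound 2 to compound 4 (within the scatter), and methoxy in place of hydrogen gives a number 2 percentage points lower from compound 1 to compound 4 (within the scatter). Compound 1, compound 4 and compound 2 thus form a series with one, two and three methoxy groups on the six-membered aromatic ring, and neither step rises above the scatter, so a methoxy group at this place makes no detectable difference at the concentration tested. Nothing at hand offers an explanation for this flat reading.

Since none of the four compounds shows an effect here, these readings cannot show whether this position would matter in a compound that does act. As far as these compounds go, what a hydroxyl group or a carboxylic acid would give on this carbon also remains open.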